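Aryl variation on the shared core: dichlorophenyl analogue

The compounds below may be only part of what the source reports. "The series", "measured", "known", "first", "only" and "open" are said of these compounds alone.

Three compounds share one core and differ only in the aryl group on a single aromatic carbon. In an assay on Sf9 cells for inhibition of protein deacetylase HDAC6 (Homo sapiens), read by fluorescence, with a stated time of 40 min, tested at 100 nM (a lower number here means less inhibition, a higher number more inhibition at the concentration tested (going by the name of the read-out)), compound 1 `Cc1ccc(-c2nc(CNc3ccc(C(=O)NO)cc3)n(-c3ccccc3)n2)cc1` gives 62.2%, compound 2 `O=C(NO)c1ccc(NCc2nc(-c3cccc(Cl)c3)nn2-c2ccccc2)cc1` gives 61.2%, and compound 3 `O=C(NO)c1ccc(NCc2nc(-c3cc4ccccc4s3)nn2-c2ccccc2)cc1` gives 65.5%. Compound 3 stands at the top of the three numbers, but the gaps are small: a number 3.3 percentage points higher from compound 1 to compound 3 (within the scatter) and a number 4.3 percentage points higher from compound 2 to compound 3 (within the scatter), both within the scatter, as is a number 1 percentage points lower from compound 1 to compound 2 (within the scatter).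

Compound 4 `O=C(NO)c1ccc(NCc2nc(-c3ccc(Cl)c(Cl)c3)nn2-c2ccccc2)cc1` is not yet measured. Its change from compound 3 is 3,4-dichlorophenyl in place of 1-benzothiophen-2-yl on an aromatic carbon. All three measured steps bear on it, since each swaps the group on that same aromatic carbon, and none moved the read-out beyond the scatter. Compound 2 carries 3-chlorophenyl at this position, and the step of a number 4.3 percentage points higher from compound 2 to compound 3 (within the scatter) was small, so a number close to compound 2 is expected for compound 4. The expected step is a number 4.5 percentage points lower from compound 3 to compound 4 (within the scatter), not beyond the scatter. For compound 4 the estimate in this assay is 61%, with a range from 50% to 72%.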

Compound 4, a percentage reported as inhibition, at one concentration (the size of the read-out at that concentration, not a potency): 34.5%
Beside the measured number, compound 4's estimate is 26.5 percentage points above it; the whole stated range lies above it.
By their numbers in this assay, from the lowest: compound 4; then compounds 2, 1 and 3 (each within the scatter of the next).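

In this assay, chloro in place of hydrogen on the aryl group gives a number 26.7 percentage points lower from compound 2 to compound 4 (beyond the scatter), showing that a single added atom at this aromatic carbon's substituent can matter, although the earlier aryl swaps all stayed within the scatter. The other two changes to 3,4-dichlorophenyl agree, with a number 31 percentage points lower from compound 3 to compound 4 (beyond the scatter) and a number 27.7 percentage points lower from compound 1 to compound 4 (beyond the scatter), so among the four compounds 3,4-dichlorophenyl alone stands apart, while 4-methylphenyl, 3-chlorophenyl and 1-benzothiophen-2-yl remain within the scatter of one another. Nothing measured here accounts for this drop.

Going by these compounds, it remains open whether the loss is specific to the added chloro or would also follow a methyl, methoxy or amine in its place. A 4-chlorophenyl group would show whether that chloro needs the 3-chloro alongside it to produce the drop.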